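A few compounds are considered here, and "the series" means these few. Any claim that something is new, unique, unknown or untested is made for them only; others in the source may bear on it.

Compound 1 `COc1ccc(OC)c(-c2nc(C(c3ccccc3)c3ccccc3)sc2CC(=O)O)c1`: 80%
Compound 2 `O=C(O)Cc1sc(C(c2ccccc2)c2ccc(F)cc2)nc1-c1ccc(Cl)cc1`: 80%
Compound 3 `O=C(O)Cc1sc(C(c2ccc(F)cc2)c2ccc(F)cc2)nc1-c1cc(F)nc(F)c1`: 80%

In an in vitro functional assay on HEK285-7 cells for antagonist activity at prostaglandin D2 receptor 2 (Homo sapiens), read by BRET and beta-arrestin recruitment (a lower number here means a smaller maximal response, a higher number a larger maximal response), compound 1 gives 80%. Compound 2 gives 80% and compound 3 gives 80%, so compound 1 stands level with both at the digits shown, and none of these differences reaches beyond the usual scatter of the assay. Going by the values given here, no pair among the three measured compounds differs in one place only, so no measured step is available to guide what a single change might do.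

Compound 4 `O=C(O)Cc1sc(C(c2ccccc2)c2ccccc2)nc1-c1ccc(C(F)(F)F)cc1` differs from compound 1 in one place: 4-(trifluoromethyl)phenyl in place of 2,5-dimethoxyphenyl on an aromatic carbon. With the three measured compounds all sitting at the same level despite wide variation at this position, compound 4 is expected to stay within the scatter, and the estimated step of no change at the digits printed from compound 1 to compound 4 (within the scatter) is expected to be none beyond it. Compound 4 is therefore expected to give 80%, in the range 66% to 92%.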

Compound 4, largest response reached (reported as efficacy), in percent of the reference or control that the assay uses: 80%
Compound 4: the middle estimate sits on the measured number at the digits printed; the range from low to high includes it.
By their numbers in this assay, from the lowest: compounds 1, 2, 3 and 4 (each within the scatter of the next).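

In this assay, going by these compounds alone, putting 4-(trifluoromethyl)phenyl in place of 2,5-dimethoxyphenyl on this aromatic carbon gives no change at the digits printed from compound 1 to compound 4 (within the scatter), the only single-place step at this position so far. The swap keeps the heavy-atom count, while the hydrogen-bond acceptors in this group go from two to none, and the maximal response shows no difference beyond the scatter. Nothing at hand explains this result. The compounds shown leave open whether an amine or a morpholine ring on this carbon would also leave the response level. They also leave open whether any change to the carboxymethyl group would do so.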